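Cytotoxicity limits across a small quinolone series

The source may report more compounds than this note shows. Statements on the series, on what has been measured and on what is new or still open speak of the compounds shown alone.

Compound 1 `COc1cc2[nH]c(C)c(-c3ccc(Oc4ccc(OC(F)(F)F)cc4)cc3)c(=O)c2cc1F` was tested in an ADME assay on HepG2 cells (Homo sapiens) for cytotoxicity, read by resazurin assay, with a stated time of 24 h; on this read-out higher numbers stand for weaker inhibition and lower numbers for stronger inhibition. In this assay compound 1 gives > 10000 nM, which is a limit of the assay rather than a number. Compound 3 `COc1cc2[nH]c(C)c(-c3ccc(Oc4ccccc4)cc3)c(=O)c2cc1F` differs from compound 1 by hydrogen in place of trifluoromethoxy on an aromatic carbon. In this assay compound 3 gives > 10000 nM, again a limit and not a number. The step that the two limits leave unreadable from compound 1 to compound 3 therefore cannot be sized. Compound 2 `Cc1[nH]c2ccccc2c(=O)c1-c1ccc(Oc2ccc(OC(F)(F)F)cc2)cc1` shares the same general build, but the difference between the two cores of compound 1 and compound 2 is not broken down here. In this assay compound 2 gives > 10000 nM, which is a limit. Compound 4 `Cc1[nH]c2ccccc2c(=O)c1-c1ccc(Oc2ccccc2)cc1` has not been measured; it differs from compound 2 by hydrogen in place of trifluoromethoxy on an aromatic carbon, the same change that separates compound 1 from compound 3. Within the data shown here, the step from compound 2 to compound 4 is expected to be a step that the limit leaves unreadable from compound 2 to compound 4, an expectation that rests on (the limit of > 10000 nM in this assay, at which 3 of the 3 values shown sit), since every value so far sits at that limit. Compound 4 is thus expected to give about 20000 nM, most likely between 8000 nM and 60000 nM.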

Compound 4, half-maximal inhibitory concentration: > 10000 nM
Compound 4 was reported as a limit (the forecaster's own chance of this, stated with the estimate: 85%); the middle value is on the limit's open side.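

Compound 2 and compound 4 both sit at a limit in this assay rather than at a number, so no size can be read for the step between them, just as none can be read between compound 1 and compound 3: the limit of > 10000 nM in this assay, at which 4 of the 4 values shown sit.

The compounds shown leave open how far each lies past that limit, and so whether swapping trifluoromethoxy for hydrogen changes cytotoxicity at all.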